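Working notes: from compound 3 to compound 4

The source may hold more compounds than are shown below. What is called first, only, known or untested is meant among the compounds shown, and "the series" means these compounds.

Measured in a functional assay on A549 cells (Homo sapiens) for antiproliferative activity, read by MTT assay, with a stated time of 72 h; a higher number here means a weaker inhibitor, a lower number a stronger inhibitor:
compound 1 `CC(C)(C)OC(=O)N1CCN(C(=S)Sc2ccc(F)cc2)CC1`: 1560 nM
compound 2 `CC(C)(C)OC(=O)N1CCN(C(=S)Sc2ccc(Cl)cc2)CC1`: 1070 nM
compound 3 `CC(C)(C)OC(=O)N1CCN(C(=S)Sc2cccc(Cl)c2)CC1`: 634 nM

Compound 3 stands at 634 nM. It lies within the scatter of its closest neighbour, as a 1.7-fold lower number from compound 2 to compound 3 (0.23 log units; within the scatter) shows, and apart from the other measured compound by a 2.5-fold lower number from compound 1 to compound 3 (0.39 log units; beyond the scatter), a modest step.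

The next structure is compound 4 `Cc1ccccc1SC(=S)N1CCN(C(=O)OC(C)(C)C)CC1`. The change is 2-methylphenyl in place of 3-chlorophenyl on a sulfur. Within the data shown here, no measured compound carries 2-methylphenyl, so the measured steps give only a rough guide to size. Among them, a 1.5-fold lower number from compound 1 to compound 2 (0.16 log units; within the scatter) stays within the scatter, and the largest change of the group on the sulfur, a 2.5-fold lower number from compound 1 to compound 3 (0.39 log units; beyond the scatter), is modest. A step of no more than modest size is therefore expected in this assay, with a weak lean towards a higher number and no firm direction. The estimated step is a 1.5-fold higher number from compound 3 to compound 4 (0.18 log units; within the scatter). For compound 4 the expected value is 950 nM, with an estimated range of 380 nM to 2300 nM.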

Compound 4, half-maximal inhibitory concentration: 2270 nM
Estimate against measurement, compound 4: 2.4-fold (0.38 log units) below; low and high end bracket the measured number.
By their numbers in this assay, from the lowest: compounds 3, 2, 1 and 4 (each within the scatter of the next, the first and the last beyond it).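

In this assay, among these compounds, the group on the sulfur can move the number further than the earlier compounds showed: 2-methylphenyl in place of 3-chlorophenyl gives a 3.6-fold higher number from compound 3 to compound 4 (0.55 log units; beyond the scatter) and is the largest step at this place so far. Replacing 4-chlorophenyl with 2-methylphenyl also gives a step beyond the scatter, a 2.1-fold higher number from compound 2 to compound 4 (0.33 log units; beyond the scatter), whereas replacing 4-fluorophenyl gives a 1.5-fold higher number from compound 1 to compound 4 (0.16 log units; within the scatter), so the methyl-bearing ring cannot be separated from the 4-fluorophenyl compound. No supporting measurement accounts for these steps.

The change from 3-chlorophenyl to 2-methylphenyl alters both the substituent and its numbered place on the ring, so the contribution of each remains unresolved. On these data alone, it also remains open how this position would respond to a ring carrying an amine or a carboxylic acid, or to a benzyl group on the sulfur.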